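Aryl substituent swap on the benzoxazol-2-amine carboxamide series

The source may hold more compounds than are shown below. What is called first, only, known or untested is meant among the compounds shown, and "the series" means these compounds.

Compound 1 `CNC(=O)c1cc(Oc2ccc3oc(Nc4cccc(C(C)C)c4)nc3c2)ccn1` and compound 2 `CNC(=O)c1cc(Oc2ccc3oc(Nc4ccc(Br)cc4)nc3c2)ccn1` differ only in the group on the aromatic amine nitrogen. In an ADME assay on Caco-2 cells (Homo sapiens) for permeability, in the apical to basolateral direction (on this read-out lower numbers stand for lower permeability and higher numbers for higher permeability), compound 1 gives 10 10^-6 cm/s and compound 2 gives 10 10^-6 cm/s, so the step of no change at the digits printed from compound 1 to compound 2 (within the scatter) shows that swapping 3-isopropylphenyl for 4-bromophenyl leaves the read-out unchanged. Within the data shown here, compound 2 therefore stands level with compound 1 and is the only close neighbour of the next analogue.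

Compound 3 `CNC(=O)c1cc(Oc2ccc3oc(Nc4ccc(OC(F)(F)F)cc4)nc3c2)ccn1` carries the change trifluoromethoxy in place of bromo on an aromatic carbon, para to a large group. Among the measured compounds shown here, only the step from compound 1 to compound 2 bears on this, and it was flat within the scatter. Compound 3 is therefore expected to give 10 10^-6 cm/s in this assay, with a range of 5 10^-6 cm/s to 20 10^-6 cm/s, the estimated step of no change at the digits printed from compound 2 to compound 3 (within the scatter) being no change beyond the scatter.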

Compound 3, apparent permeability: 10 10^-6 cm/s
Beside the measured number, compound 3's estimate shows no gap at the digits printed, and the stated range covers the measured number.
By their numbers in this assay, from the lowest: compounds 1, 2 and 3 (each within the scatter of the next).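

In this assay, trifluoromethoxy in place of bromo on an aromatic carbon, para to a large group, gives no change at the digits printed from compound 2 to compound 3 (within the scatter). Unlike the earlier step, which exchanged one whole substituted phenyl for another, this one changes only the group at a single place on the ring, and five heavy atoms with one hydrogen-bond acceptor entering for a single bromine leave the read-out flat at the digits printed. No supporting data bear on why this exchange leaves the read-out flat.

The compounds shown leave open whether a carboxylic acid or a primary amine at this same place would shift the read-out. They also leave open whether the flat read-out would hold for a change elsewhere in the molecule, such as on the methyl amide.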